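The source may report more compounds than this note shows. Statements on the series, on what has been measured and on what is new or still open speak of the compounds shown alone.

Compounds measured so far:

- compound 1, `COc1c(C)ccc2c1CCC2c1ncc[nH]1`, gives 40%
- compound 2, `c1ccc2c(c1)CCCC2c1ncc[nH]1`, gives 71%
- compound 3, `Cc1ccc2c(c1NS(C)(=O)=O)CCC2c1ncc[nH]1`, gives 83%

All three were tested in a functional assay on CHO cells for agonist activity at Alpha-1A adrenergic receptor (Homo sapiens), read by FLIPR and calcium flux; a lower number here means a smaller maximal response, a higher number a larger maximal response. Compound 1 stands lowest of the three numbers shown: compound 2 lies closest to it, a number higher than compound 1 by a margin beyond the scatter, and compound 3 lies furthest, as the step of a number 43 percentage points higher from compound 1 to compound 3 (beyond the scatter) shows, a large rise in the largest response reached.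

The compound still to be measured is compound 4, `COc1c(Cl)ccc2c1CCC2c1ncc[nH]1`. It differs from compound 1 in one place: chloro in place of methyl on an aromatic carbon. The methoxy group and the rest of the shared core stay as they are.

Going by the values given here, the only measured step, from compound 1 to compound 3, swaps a methoxy for a methanesulfonamido and is large, but it does not touch the methyl that is replaced here, so no measured step bears directly on a chloro in place of methyl. With no guide from the numbers, the step of a number 5 percentage points higher from compound 1 to compound 4 (within the scatter) is expected to stay small, and compound 4 is estimated at 45%, most likely between 25% and 70%.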

Compound 4, largest response reached (Emax), in percent of the reference or control that the assay uses: 24%
Compound 4: the middle estimate sits 21 percentage points above what was measured; the whole stated range lies above it.
By their numbers in this assay, from the lowest: compound 4; then compound 1; then compound 2; then compound 3.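

In this assay, the aromatic carbon ortho to a methoxy group proves sensitive to what it carries: chloro in place of methyl gives a number 16 percentage points lower from compound 1 to compound 4 (beyond the scatter), a modest step. Methyl and chloro each count 1 heavy atom, with no hydrogen-bond donor or acceptor, so even a swap this small on paper moves the largest response reached, whereas the only earlier step changed the methoxy group itself. Nothing measured here explains why this change lowers the response.

From the compounds shown here alone, whether a bromo, a trifluoromethyl or an amine on this carbon would lower the response further or raise it stays open. Also open, going by these compounds, is whether chloro would have a similar effect with methanesulfonamido in place of methoxy, as in compound 3, which gives 83%.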